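The compounds below may be only part of what the source reports. "The series", "measured", "known", "first", "only" and "open" are said of these compounds alone.

Notes on the series. Compound 1 `Cc1ccc(Cn2cc(CSC(=S)N3CCN(C(=O)OCc4ccccc4)CC3)nn2)cc1` in a functional assay on PC-3 cells (Homo sapiens) for inhibition, read by MTT assay, with a stated time of 72 h (a higher number here means a weaker inhibitor, a lower number a stronger inhibitor), gives > 128000 nM, which is a limit of the assay and not a number. Compound 2 `O=C(OCc1ccccc1)N1CCN(C(=S)SCc2cn(Cc3ccc(F)cc3)nn2)CC1` in this assay likewise gives > 128000 nM, again only a limit. The step that the two limits leave unreadable from compound 1 to compound 2 is therefore unreadable, since both ends sit at the limit (the limit of > 128000 nM in this assay, at which 2 of the 2 values shown sit). Compound 2 thus stands at the limit of the assay, with no numerical position among the values shown. Compound 3 `O=C(OCc1ccccc1)N1CCN(C(=S)SCc2cn(Cc3ccccc3F)nn2)CC1` differs from compound 2 by 2-fluorophenyl in place of 4-fluorophenyl on a saturated chain carbon bound to an aromatic nitrogen. No measured step bears directly on this change, and the one step shown is of unreadable size. With both measured compounds at the limit, a step that the limit leaves unreadable from compound 2 to compound 3 of no size beyond the scatter is expected for compound 3. The estimate for compound 3 in this assay is 250000 nM, with a range from 100000 nM to 600000 nM, most likely reported as a limit again.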

Compound 3, half-maximal inhibitory concentration: 68300 nM
The estimate for compound 3 lay 3.7-fold (0.56 log units) above the measured number; the measured number lies below the stated range.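

In this assay, within the data shown here, compound 3 is the only one of the three compounds with a number and not a limit, so this position on the saturated chain carbon bound to an aromatic nitrogen can respond to where the fluorine sits on the ring: the limit of > 128000 nM in this assay, at which 2 of the 3 values shown sit. 2-Fluorophenyl in place of 4-fluorophenyl gives an at least 1.8-fold lower number from compound 2 to compound 3 (0.27 log units; that floor lies within the scatter), and 2-fluorophenyl in place of 4-methylphenyl gives an at least 1.8-fold lower number from compound 1 to compound 3 (0.27 log units; that floor lies within the scatter). Both are floors that do not fix the true size of either change, and the step between the two limit compounds cannot be read.

The compounds shown leave open whether the fluorine itself matters or whether any group at that ring position would serve. A 2-chlorophenyl or 2-methylphenyl, set against an unsubstituted phenyl, would separate these readings.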